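Ether side chain variation in a GPR39 agonist series

This account rests on a few compounds, and the source may have more. Where it says the series, first, only, none or still open, it means among the compounds named here.

Measured so far in a functional assay on HEK293 cells for agonist activity at G-protein coupled receptor 39 (Homo sapiens), read by scintillation proximity assay and inositol phosphate accumulation, with a stated time of 75 min; on this read-out higher numbers stand for an effect only at larger amounts of compound and lower numbers for an effect already at smaller amounts:
Compound 1 `Cc1nn(-c2ncnc3nc[nH]c23)c2c1C(OCc1ccc(Cl)cc1Cl)CC(=O)N2`: 243 nM
Compound 2 `Cc1nn(-c2ncnc3nc[nH]c23)c2c1C(C(=O)NCc1ccccc1)CC(=O)N2`: 2930 nM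
Compound 3 `Cc1nn(-c2ncnc3nc[nH]c23)c2c1C(OCc1ccc(C(C)C)cc1)CC(=O)N2`: 1690 nM

Compound 3 gives the second-highest of the three numbers. Its nearest neighbour is compound 2, within the usual scatter of this assay. Compound 1 sits well apart: a 7.0-fold higher number from compound 1 to compound 3 (0.84 log units; beyond the scatter).

Compound 4 `Cc1nn(-c2ncnc3nc[nH]c23)c2c1C(OCCn1nccc1C)CC(=O)N2` is not yet measured. The change from compound 3 is (5-methyl-1H-pyrazol-1-yl)methyl in place of 4-isopropylphenyl on a saturated chain carbon bound to an oxygen on a saturated carbon. Going by the values given here, the steps that bear on it both leave the 2,4-dichlorophenyl-bearing compound 1 and raise the number: a 7.0-fold higher number from compound 1 to compound 3 (0.84 log units; beyond the scatter) and a 12-fold higher number from compound 1 to compound 2 (1.08 log units; beyond the scatter). Neither touches a pyrazolyl group, so the direction of this particular replacement is not covered. The expectation for compound 4 in this assay is a number close to that of compound 3, with a 1.5-fold higher number from compound 3 to compound 4 (0.17 log units; within the scatter) not expected to exceed the scatter. The estimate for compound 4 is 2500 nM, with a range of 800 nM to 8000 nM.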

Compound 4, half-maximal effective concentration: 1620 nM
For compound 4 the middle estimate is 1.5-fold (0.19 log units) above the measured one; measured number inside the range.
By their numbers in this assay, from the lowest: compound 1; then compounds 4, 3 and 2 (each within the scatter of the next).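

In this assay, (5-methyl-1H-pyrazol-1-yl)methyl serves on this chain carbon about as 4-isopropylphenyl does, with a 1.0-fold lower number from compound 3 to compound 4 (0.02 log units; within the scatter) within the scatter, so a five-membered aromatic ring with 2 hetero atoms and a six-membered ring of carbon only are not told apart here. The link to the amide compound holds too, with a 1.8-fold lower number from compound 2 to compound 4 (0.26 log units; within the scatter) also within the scatter, while 2,4-dichlorophenyl remains apart, with a 6.7-fold higher number from compound 1 to compound 4 (0.82 log units; beyond the scatter) beyond the scatter. No evidence bearing on this result is available.

Open, going by these compounds, is how an amine or a carboxylic acid on this chain would read. Also open, on these data alone, is whether a single chlorine on the phenyl ring would match 2,4-dichlorophenyl.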